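Adding a Second Methoxy Group to a Non-Cytotoxic Scaffold

The compounds below may be only part of what the source reports. "The series", "measured", "known", "first", "only" and "open" are said of these compounds alone.

Two compounds share a core in which a methoxy-bearing bicyclic aryl ether is linked to an aminopyrimidine carrying a nitrile-substituted aniline: compound 1 `COc1c(Oc2ccnc(Nc3ccc(C#N)cc3)n2)ccc2cc(C#N)ccc12` and compound 2 `COc1cc2cc(C#N)ccc2cc1Oc1ccnc(Nc2ccc(C#N)cc2)n1`. Both were tested in an ADME assay on MT4 cells (Homo sapiens) for cytotoxicity, read by MTT assay, with a stated time of 4 days; a higher number here means that more compound is tolerated, a lower number that less compound is tolerated. Compound 1 gives > 211000 nM, which is a limit of the assay rather than a number. Compound 2 gives > 318000 nM, likewise a limit and not a number. Compound 2 therefore stands at the ceiling of what the assay reports, as the limit of > 318000 nM in this assay, at which 1 of the 2 values shown sits, shows, and compound 1 sits at its own ceiling, as the limit of > 211000 nM in this assay, at which 1 of the 2 values shown sits, shows.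

Compound 3 `COc1cc2cc(C#N)ccc2c(OC)c1Oc1ccnc(Nc2ccc(C#N)cc2)n1` differs from compound 2 by methoxy in place of hydrogen on an aromatic carbon. Among the measured compounds shown here, with no measured step available, the expected change from compound 2 to compound 3 is an at least 1.0-fold lower number from compound 2 to compound 3 (0.02 log units; that floor lies within the scatter), none beyond the scatter. Compound 3 is therefore estimated at 300000 nM, within 100000 nM to 1000000 nM.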

Compound 3, half-maximal cytotoxic concentration: > 118000 nM
Compound 3 was reported as a limit; the forecaster's own chance of this, stated with the estimate: 80%; the middle value is on the limit's open side.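

In this assay compound 3 gives > 118000 nM, which is a limit and not a number. Compound 1 and compound 2 also carry limits, so the steps from each of them to compound 3 cannot be read. The compounds shown leave open whether the added methoxy changes tolerated concentration at all.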